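The source may hold more compounds than are shown below. What is called first, only, known or untested is meant among the compounds shown, and "the series" means these compounds.

Measured in a functional assay on B16-F10 cells (Mus musculus) for antiproliferative activity, read by MTT assay, with a stated time of 72 h; on this read-out lower numbers stand for stronger inhibition and higher numbers for weaker inhibition:
- compound 1 `CCCCCCCCCCCNC[C@@H]1OC[C@H](N)[C@@H]1O` gives 19300 nM
- compound 2 `CCCCCCCCCCCCNC[C@@H]1OC[C@H](N)[C@H]1O` gives 58100 nM
- compound 3 `CCCCCCCNC[C@@H]1OC[C@H](N)[C@H]1O` gives > 128000 nM (a limit, not a number)

For compound 3 there is only a limit and no number: the limit of > 128000 nM in this assay, at which 1 of the 3 values shown sits. Compound 4 `CCCCCCCCCCCNC[C@@H]1OC[C@H](N)[C@H]1O` differs from compound 3 by a single change, (butyl in place of hydrogen on a saturated chain carbon, seven bonds along the chain from an amine nitrogen), which puts butyl in place of hydrogen on a saturated chain carbon, seven bonds along the chain from an amine nitrogen.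

Among the compounds with values here, one measured step bears on this, and it runs the opposite way. It swaps pentyl for hydrogen at that same place and gives an at least 2.2-fold higher number from compound 2 to compound 3 (0.34 log units; beyond the scatter), which is beyond the scatter. Adding butyl is close to reversing that step, so a move to a lower number, meaning stronger inhibition, seems likely. Its size is uncertain because compound 3 has only a limit. Compound 1 gives 19300 nM, which keeps lower numbers in play.

The expected result is an at least 2.1-fold lower number from compound 3 to compound 4 (0.32 log units; beyond the scatter), at least a modest step. Compound 4 is estimated at 60000 nM, with an expected range from 25000 nM to 125000 nM.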

Compound 4, half-maximal inhibitory concentration: 88800 nM
Estimate against measurement, compound 4: 1.5-fold (0.17 log units) below; the measured number falls inside the stated range.
By their numbers in this assay, from the lowest: compound 1; then compounds 2 and 4 (each within the scatter of the next). At a limit, above all of these: compound 3.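

In this assay, butyl on this saturated chain carbon, seven bonds along the chain from an amine nitrogen, gives an at least 1.4-fold lower number from compound 3 to compound 4 (0.15 log units; that floor lies within the scatter), and the starting point of that step is only a limit: the limit of > 128000 nM in this assay, at which 1 of the 4 values shown sits.

Hydrogen in place of methyl on a saturated chain carbon gives a 1.5-fold higher number from compound 2 to compound 4 (0.18 log units; within the scatter), so these two chain lengths cannot be told apart in this assay.

A single stereocentre at a saturated ring carbon, drawn S in one compound and R in the other, gives a 4.6-fold higher number from compound 1 to compound 4 (0.66 log units; beyond the scatter), the only new step beyond the scatter, and this comparison isolates configuration: the fact that compounds 1 and 4 differ only in the configuration as drawn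

Going by these compounds, how the number would move with a longer chain, or with a carboxylic acid at this place, stays open. Also open, on these data alone, is whether the S configuration would give a lower number on the chains of compound 2 or compound 3.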